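The compounds below may be only part of what the source reports. "The series", "measured", "known", "first", "only" and "open" are said of these compounds alone.

Measured so far:
compound 1, `O=Cc1cn(-c2ccccc2)nc1-c1ccc(Cl)cc1`: 90%
compound 2, `COc1cc(/C=C/C(=O)C(=Cc2cn(-c3ccccc3)nc2-c2ccc([N+](=O)[O-])cc2)C(=O)/C=C/c2ccc(O)c(OC)c2)ccc1O`: 92%

In a functional assay on MCF7 cells (Homo sapiens) for antiproliferative activity, read by MTT assay, with a stated time of 24 h, tested at 0.1 ug/mL (a lower number here means a stronger effect, a higher number a weaker effect of the compound at the concentration tested), compound 2 gives the higher of the two numbers, but its nearest neighbour, compound 1, lies within the scatter, so the two show no real difference. Compound 3, `COc1cc(/C=C/C(=O)C(=Cc2cn(-c3ccccc3)nc2-c2cccc([N+](=O)[O-])c2)C(=O)/C=C/c2ccc(O)c(OC)c2)ccc1O`, is not yet measured. It differs from compound 2 in one place: 3-nitrophenyl in place of 4-nitrophenyl on an aromatic carbon. Within the data shown here, no measured pair shows what this change does. The step from compound 2 to compound 3 is therefore expected to stay within the scatter, with no clear direction: a number 2 percentage points lower from compound 2 to compound 3 (within the scatter). For compound 3 in this assay the estimate is 90%, in a range from 78% to 100%.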

Compound 3, a percentage reported as activity, at one concentration (the size of the read-out at that concentration, not a potency): 85%
Estimate against measurement, compound 3: 5 percentage points above; the range from low to high includes it.
By their numbers in this assay, from the lowest: compounds 3, 1 and 2 (each within the scatter of the next).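

Placing 3-nitrophenyl instead of 4-nitrophenyl on the aromatic carbon of the five-membered ring gives, in this assay, a number 7 percentage points lower from compound 2 to compound 3 (within the scatter). Among these compounds, this is the first measured pair for this change, and it shows no real difference between the two nitrophenyl groups at this position at the single concentration tested. No available measurement bears on this result.

The compounds shown leave open whether a different group on this phenyl ring, such as an amine or a carboxylic acid, would move the number beyond the scatter. They also leave open whether these two compounds would differ at other concentrations.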